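Compound 4: dimethylaminophenoxy in place of isopentyl

The compounds below may be only part of what the source reports. "The series", "measured", "known", "first", "only" and "open" are said of these compounds alone.

Compound 3 `COc1cccc(CNCCCNc2ccnc3cc(CCC(C)C)ccc23)c1O` gives 4200 nM in a physicochemical assay for solubility, with a stated time of 18 h, at pH 7.4 (a higher number here means a more soluble compound, a lower number a less soluble compound), the lowest of the three numbers; compound 2 `COc1cccc(Oc2ccc3c(NCCCNCc4cccc(OC)c4O)ccnc3c2)c1` gives 14500 nM and compound 1 `COc1cccc(CNCCCNc2ccnc3cc(-c4ccc(F)cc4)ccc23)c1O` gives 32000 nM. Compound 4 `COc1cccc(CNCCCNc2ccnc3cc(Oc4cccc(N(C)C)c4)ccc23)c1O` differs from compound 3 by 3-(dimethylamino)phenoxy in place of isopentyl on an aromatic carbon. Within the data shown here, the steps that bear on this are a 3.5-fold lower number from compound 2 to compound 3 (0.54 log units; beyond the scatter) and a 7.6-fold lower number from compound 1 to compound 3 (0.88 log units; beyond the scatter), which leave the isopentyl compound as the least soluble of the set, while a 2.2-fold lower number from compound 1 to compound 2 (0.34 log units; beyond the scatter) separates the two aryl-bearing compounds only modestly. Returning from isopentyl to an aryloxy group is therefore expected to raise the number in this assay. Reversing the direction of a 3.5-fold lower number from compound 2 to compound 3 (0.54 log units; beyond the scatter) gives the expected step of a 3.3-fold higher number from compound 3 to compound 4 (0.52 log units; beyond the scatter). For compound 4 the expected solubility is 14000 nM, within a range from 5000 nM to 40000 nM.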

Compound 4, solubility: 14500 nM
Compound 4: middle estimate off by 1.0-fold (0.02 log units), on the low side; low and high end bracket the measured number.
By their numbers in this assay, from the lowest: compound 3; then compounds 2 and 4 (each within the scatter of the next); then compound 1.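

In this assay, dimethylamino in place of methoxy on an aromatic carbon gives no change at the digits printed from compound 2 to compound 4 (within the scatter), so these two substituents are not told apart here. The step up from isopentyl recurs with a second aryloxy group, a 3.5-fold higher number from compound 3 to compound 4 (0.54 log units; beyond the scatter), while the gap to the 4-fluorophenyl group also persists, a 2.2-fold lower number from compound 1 to compound 4 (0.34 log units; beyond the scatter). Nothing available explains these steps. Open, on these data alone, is whether a carboxylic acid or a morpholine in place of dimethylamino would leave the number at the level of compound 2 and compound 4.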